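A few compounds are considered here, and "the series" means these few. Any claim that something is new, unique, unknown or untested is made for them only; others in the source may bear on it.

Compound 1, `CC(=O)N(Cc1ncnc2c1ncn2[C@@H]1O[C@H](CO)[C@@H](O)[C@H]1O)C1CCCCC1` — > 100000 nM
Compound 2, `OC[C@H]1O[C@@H](n2cnc3c(CSc4ccccn4)ncnc32)[C@H](O)[C@@H]1O` — > 100000 nM
Compound 3, `CC(=O)N(Cc1ncnc2c1ncn2[C@H]1C[C@H](O)[C@@H](CO)O1)C1CCCCC1` — > 100000 nM

All three compounds have been run in a functional assay on Huh-7 cells (Homo sapiens) for cytotoxicity, read by MTT assay, with a stated time of 3 days; on this read-out higher numbers stand for lower toxicity in this test and lower numbers for higher toxicity in this test. For compound 2 the read-out is a limit of the test, > 100000 nM, and no number was reached. For compound 1 the result is likewise a limit, > 100000 nM. For compound 3 the result is again a limit, > 100000 nM. Going by the values given here, the one pair that differs in a single place, compound 1 and compound 3, therefore gives a step that the two limits leave unreadable from compound 1 to compound 3, a step whose size cannot be read. The whole picture of the measured set is the limit of > 100000 nM in this assay, at which 3 of the 3 values shown sit.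

The unmeasured compound 4, `OC[C@H]1O[C@@H](n2cnc3c(CN4CCCCC4)ncnc32)[C@H](O)[C@@H]1O`, is built from compound 2 by piperidin-1-yl in place of (pyridin-2-yl)sulfanyl on a saturated chain carbon bound to an aromatic carbon. Among the compounds with values here, no measured step touches this change: the only step in the set, from compound 1 to compound 3, concerns a different position and is itself unreadable. What remains is that every measured compound, including compound 2, sits at the limit of this assay. Compound 4 is therefore expected to sit at that limit as well, with a number no higher from compound 2 to compound 4 (the limit leaves the size open) expected to be no step beyond the scatter. The estimate for compound 4 in this assay is 100000 nM, expected to fall between 30000 nM and 300000 nM.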

Compound 4, half-maximal cytotoxic concentration: 87000 nM
The estimate for compound 4 lay 1.1-fold (0.06 log units) above the measured number; the range from low to high includes it.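

In this assay, going by these compounds alone, compound 4 gives 87000 nM, the only value in the set that is an actual number, and it shows that this position can yield a reading inside the range of the test. Placing piperidin-1-yl in place of (pyridin-2-yl)sulfanyl on a saturated chain carbon bound to an aromatic carbon gives an at least 1.1-fold lower number from compound 2 to compound 4 (0.06 log units; that floor lies within the scatter), so the change can be read only as a floor, and that floor does not separate the two compounds. Neither the aromatic ring with its sulfur link nor the non-aromatic ring bound through nitrogen brings the reading away from the upper edge of what the test can read, as the set as a whole shows: the limit of > 100000 nM in this assay, at which 3 of the 4 values shown sit.

As far as these compounds go, how far compound 4 really lies from compound 2 remains open, and the step that touches the sugar ring, between compound 1 and compound 3, cannot be read either. Also open, from the compounds shown here alone, is whether a different group on the same carbon, such as an open-chain amine like dimethylamino or a carboxylic acid, would give a number clearly lower in this assay.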